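Replacing 4-methoxyphenyl with 3-nitrophenyl on an aromatic nitrogen

This account rests on a few compounds, and the source may have more. Where it says the series, first, only, none or still open, it means among the compounds named here.

Compounds measured so far in a functional assay on B16 cells (Mus musculus) for cytotoxicity, read by MTT assay, with a stated time of 48 h; a higher number here means a weaker inhibitor, a lower number a stronger inhibitor:
- compound 1 `C#CC1=CC[C@]2(CC1)C(=C)CC[C@H]2C(C)C` gives 123000 nM
- compound 2 `C=C1CCC[C@]2(C)CCC(c3cn(-c4ccc(OC)cc4)nn3)=CC[C@@]12C` gives 209000 nM

Within the data shown here, only these two compounds have numbers so far. Compound 2 (209000 nM) stands level with compound 1 (123000 nM), as the two values lie within the usual scatter of each other. Attention now turns to compound 3 (`C=C1CCC[C@]2(C)CCC(c3cn(-c4cccc([N+](=O)[O-])c4)nn3)=CC[C@@]12C`), which keeps the core of compound 2 and carries 3-nitrophenyl in place of 4-methoxyphenyl on an aromatic nitrogen.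

Among the measured compounds shown here, no measured pair shows what an exchange at this aromatic nitrogen does, so the data offer no direct guide to its size or direction. The expectation therefore rests on the value of compound 2 (209000 nM), and no step beyond the scatter is expected in this assay. The estimate corresponds to an expected step (a 1.3-fold lower number from compound 2 to compound 3 (0.12 log units; within the scatter)) that is small and uncertain in direction. The estimated value for compound 3 is 160000 nM, with an expected range from 60000 nM to 400000 nM in this estimate.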

Compound 3, half-maximal inhibitory concentration: 31700 nM
Compound 3: middle estimate off by 5.0-fold (0.70 log units), on the high side, and the stated range ends above it.
By their numbers in this assay, from the lowest: compound 3; then compounds 1 and 2 (each within the scatter of the next).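

Among these compounds, the exchange of 4-methoxyphenyl for 3-nitrophenyl on the aromatic nitrogen gives the first step in this assay that can be read across a single change, a 6.6-fold lower number from compound 2 to compound 3 (0.82 log units; beyond the scatter), and this step lies beyond the scatter. It shows that the group on this nitrogen, two ring bonds from the ring atom that bears a large group, can shift the number in this assay while the rest of compound 2 stays in place, something compound 1 and compound 2 could not show, as they differ in more than one place. Nothing at hand bears on why the number falls with this exchange.

The group on the phenyl ring and its place on that ring change together in this step, so the compounds shown cannot separate the two, and 3-methoxyphenyl or 4-nitrophenyl on the same nitrogen would be needed to do so. They also leave open how this nitrogen would respond to other groups, such as an aminophenyl, a carboxylic acid on the phenyl ring or a longer alkyl chain in place of the phenyl ring.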